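Ketone-linked cinnamic acid to saturated acid: compound 4

The source may hold more compounds than are shown below. What is called first, only, known or untested is meant among the compounds shown, and "the series" means these compounds.

Measured compounds:
- compound 1, `CC1(C)CCC(C)(C)c2cc(C(=O)c3ccc(/C=C/C(=O)O)cc3)ccc21`, > 5000 nM
- compound 2, `CC1(C)CCC(C)(C)c2cc(Cc3ccc(CCC(=O)O)cc3)ccc21`, 1700 nM
- compound 3, `CC1(C)CCC(C)(C)c2cc(C3(c4ccc(CCC(=O)O)cc4)OCCO3)ccc21`, 14500 nM

In an assay on Sf9 cells for inhibition of cytochrome P450 26B1 (Homo sapiens), read by HPLC, using microsomes and NADPH, with a stated time of 5 min, in the presence of a further agent that is not named here (on this read-out lower numbers stand for stronger inhibition and higher numbers for weaker inhibition), compound 1 returns only a limit, > 5000 nM, and no number; this is the limit of > 5000 nM in this assay, at which 1 of the 3 values shown sits. Within the same assay, compound 2 gives 1700 nM and compound 3 gives 14500 nM, so the two saturated-acid analogues span a wide stretch of the read-out depending on the linker between the shared core and the phenyl ring.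

Compound 4, `CC1(C)CCC(C)(C)c2cc(C(=O)c3ccc(CCC(=O)O)cc3)ccc21`, keeps the carbonyl linker of compound 1 and differs from it by 2-carboxyethyl in place of 2-carboxyethenyl on an aromatic carbon; in words: 2-carboxyethyl in place of 2-carboxyethenyl on an aromatic carbon. Among the measured compounds shown here, no measured pair shows this change directly, and the value of compound 1 is a limit, so the size of the step is open. Compound 2 carries the 2-carboxyethyl chain and gives 1700 nM, and compound 3, with the same chain, gives 14500 nM. A number somewhere in that region is the reasonable expectation for compound 4.

Compound 4 is expected at 5000 nM, between 1500 nM and 20000 nM, with the estimated step of a number no higher from compound 1 to compound 4 (the limit leaves the size open) uncertain in direction given that compound 1 stands only at a limit.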

Compound 4, half-maximal inhibitory concentration: > 5000 nM
Compound 4 was reported as a limit; the forecaster's own chance of this, stated with the estimate: 40%; the middle value lies on the limit itself.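

Compound 1 and compound 4 are both reported only as limits, so no step between them can be read: the limit of > 5000 nM in this assay, at which 2 of the 4 values shown sit.

Going by these compounds, whether 2-carboxyethyl in place of 2-carboxyethenyl changes inhibition on the carbonyl-linked compounds, in either direction or by any size, stays open.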